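Chloro to methyl swap across two thioether cores

The source may report more compounds than this note shows. Statements on the series, on what has been measured and on what is new or still open speak of the compounds shown alone.

Compound 2 `O=C(CSc1nnnn1-c1ccccc1)N/N=c1/scc(-c2ccc(Cl)cc2)n1-c1ccccc1` and compound 3 `O=C(CSc1ncccn1)N/N=c1/scc(-c2ccc(Cl)cc2)n1-c1ccccc1` share the chloro-bearing ring and differ only in the group on the sulfur; the difference between their cores is pyrimidin-2-yl in place of 1-phenyl-1H-tetrazol-5-yl on a sulfur. In a functional assay on C6 cells (Rattus norvegicus) for cytotoxicity, read by MTT assay, with a stated time of 24 h, tested at 50 ug/mL (on this read-out higher numbers stand for a weaker effect at the one concentration tested and lower numbers for a stronger effect), compound 2 gives 60% and compound 3 gives 61.8%; the step of a number 1.8 percentage points higher from compound 2 to compound 3 (within the scatter) lies within the scatter, so the two cores read alike here. Compound 1 `Cc1ccc(-c2cs/c(=N/NC(=O)CSc3nnnn3-c3ccccc3)n2-c2ccccc2)cc1` carries the change methyl in place of chloro on an aromatic carbon on the core of compound 2; in this assay compound 1 gives 29.5%, and the step of a number 30.5 percentage points lower from compound 2 to compound 1 (beyond the scatter) lies beyond the scatter. Compound 4 `Cc1ccc(-c2cs/c(=N/NC(=O)CSc3ncccn3)n2-c2ccccc2)cc1` is not yet measured; it carries the change methyl in place of chloro on an aromatic carbon on the core of compound 3, the same change at the same place as from compound 2 to compound 1, and this change occurs twice among the four compounds. Among the compounds with values here, for compound 4 a step of about the earlier size is expected, a number 29.8 percentage points lower from compound 3 to compound 4 (beyond the scatter), because the one measured occurrence a number 30.5 percentage points lower from compound 2 to compound 1 (beyond the scatter) was large and the two cores differ by no more than a number 1.8 percentage points higher from compound 2 to compound 3 (within the scatter). Only one occurrence is measured, so the expectation carries wide bounds. Compound 4 is therefore estimated at 32%, with a range from 18% to 48%.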

Compound 4, a percentage reported as activity, at one concentration (the size of the read-out at that concentration, not a potency): 64.4%
Compound 4: the middle estimate sits 32.4 percentage points below what was measured; the measured number lies above the stated range.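

In this assay, methyl in place of chloro does not carry from the core of compound 2 to the core of compound 3, where the step is a number 2.6 percentage points higher from compound 3 to compound 4 (within the scatter): the same change on two cores in this assay, a number 30.5 percentage points lower (beyond the scatter) from compound 2 to compound 1 and a number 2.6 percentage points higher (within the scatter) from compound 3 to compound 4, 33.1 percentage points apart, beyond the scatter of two such steps

Read the other way, pyrimidin-2-yl in place of 1-phenyl-1H-tetrazol-5-yl gives a step on the methyl-bearing pair, a number 34.9 percentage points higher from compound 1 to compound 4 (beyond the scatter), that differs from the one on the chloro-bearing pair: the same change on two cores in this assay, a number 1.8 percentage points higher (within the scatter) from compound 2 to compound 3 and a number 34.9 percentage points higher (beyond the scatter) from compound 1 to compound 4, 33.1 percentage points apart, beyond the scatter of two such steps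

Within the data shown here, the two changes therefore cannot be treated as independent in these four compounds, but the whole departure rests on the single value of compound 1, and the data show neither why the change depends on the core nor which behaviour would hold on a third core.

The compounds shown leave open whether a fluoro or a methoxy in place of the chloro would follow the large step seen with the 1-phenyl-1H-tetrazol-5-yl group. Going by these compounds, it also remains open whether a pyridin-2-yl or a benzyl on the sulfur would behave like either of the two groups here.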